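A few compounds are considered here, and "the series" means these few. Any claim that something is new, unique, unknown or untested is made for them only; others in the source may bear on it.

Series notes, step from compound 2 to compound 3.

Compound 1 `CC/N=C(/NC#N)NCCCn1nc(-c2ccccc2)ccc1=O` and compound 2 `CC/N=C(\S)NCCCn1nc(-c2ccccc2)ccc1=O` share the same core and differ only at the amine nitrogen. In a functional assay on the whole organism with Rattus norvegicus as the target, at a dose of 100 mg/kg (a lower number here means less inhibition, a higher number more inhibition at the dose given (going by the name of the read-out)), compound 1 gives 62.9%, and in the same assay compound 2 gives 39%. The step of a number 23.9 percentage points lower from compound 1 to compound 2 (beyond the scatter) is the only measured one, and on it compound 2 stands lowest of the two numbers, with compound 1 as its nearest neighbour above.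

Compound 3 `C/N=C(\S)N(C)CCCCn1nc(-c2ccccc2)ccc1=O` is not yet measured. It differs from compound 2 in that (a group of 7 heavy atoms (4 carbon, 2 nitrogen, 1 sulfur; no ring) in place of a group of 6 heavy atoms (3 carbon, 2 nitrogen, 1 sulfur; no ring), on a saturated chain carbon, three bonds along the chain from an aromatic nitrogen). Going by the values given here, the one measured step concerns a change on the amine nitrogen, not on the saturated chain carbon, so it does not bear directly on this change; it only shows that altering the group at that end of the chain moved the read-out by a modest amount. Among the compounds with values here, no step with a shared change is available. A step of similar or smaller size is therefore expected in this assay, with no firm direction; a slight further decrease is taken as the middle case. The estimated change is a number 6 percentage points lower from compound 2 to compound 3 (within the scatter). For compound 3 the expected value is 33%, within a range from 12% to 55%.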

Compound 3, a percentage reported as inhibition, in the whole organism at one dose (the size of the read-out at that dose, not a potency): 17.5%
The estimate for compound 3 lay 15.5 percentage points above the measured number; low and high end bracket the measured number.
By their numbers in this assay, from the lowest: compound 3; then compound 2; then compound 1.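

In this assay, the change on the saturated chain carbon, three bonds along the chain from an aromatic nitrogen, moves the read-out on its own: a number 21.5 percentage points lower from compound 2 to compound 3 (beyond the scatter). This step is rated modest, as is the earlier one at the amine nitrogen, a number 23.9 percentage points lower from compound 1 to compound 2 (beyond the scatter), so both places in this part of the molecule have now shown a change beyond the scatter, and here the direction is downward, where the earlier notes could fix none. Across the wider pair the fall is large, a number 45.4 percentage points lower from compound 1 to compound 3 (beyond the scatter), which puts compound 3 lowest of the three and compound 1 highest, though no measurement on hand says what lies behind either fall.

The step from compound 2 to compound 3 swaps a group of 6 heavy atoms with 2 hydrogen-bond donors for one of 7 heavy atoms with 1 hydrogen-bond donor, and the compounds shown do not separate these two differences. On these data alone, how the nitrile-bearing group of compound 1 would read on the same longer arrangement, or how a longer chain ending in a primary amine or a carboxylic acid would read, remains open.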